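The source may hold more compounds than are shown below. What is called first, only, known or untested is meant among the compounds shown, and "the series" means these compounds.

Compound 1 `CN(C)C(=O)Nc1cccc([N+](=O)[O-])c1` and compound 3 `CN(C)C(=O)Nc1ccc([N+](=O)[O-])cc1` are built from the same atoms joined differently; how the two cores differ is not broken down here. In a physicochemical assay for lipophilicity (on this read-out higher numbers stand for higher lipophilicity and lower numbers for lower lipophilicity), compound 1 gives 1.33, while compound 3 gives 1.43, the two values lying within the usual scatter of each other. Compound 2 `CN(C)C(=O)Nc1cccc(C#N)c1` differs from compound 1 by cyano in place of nitro on an aromatic carbon, the cyano standing meta to a group of 6 heavy atoms, and in this assay compound 2 gives 0.98, the step being a number 0.35 log units lower from compound 1 to compound 2 (beyond the scatter). Compound 4 `CN(C)C(=O)Nc1ccc(C#N)cc1` differs from compound 3 by cyano in place of nitro on an aromatic carbon, here para to a group of 6 heavy atoms, so this is the same kind of change rather than the same one. For compound 4 a step of a number 0.35 log units lower from compound 3 to compound 4 (beyond the scatter) is expected, resting on the measured step of a number 0.35 log units lower from compound 1 to compound 2 (beyond the scatter). Compound 4 is thus estimated at 1.08, between 0.85 and 1.3.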

Compound 4, partition coefficient: 0.97
Beside the measured number, compound 4's estimate is 0.11 log units above it; the measured number falls inside the stated range.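

In this assay, cyano in place of nitro gives a number 0.46 log units lower from compound 3 to compound 4 (beyond the scatter), and the same kind of change on the other core gives a number 0.35 log units lower from compound 1 to compound 2 (beyond the scatter), so the direction of the step carries over between these two cores. This rests on just two pairs, so it shows the step repeating here and does not show that it would hold on any other core. Nothing shown here explains why the number falls in either pair. The compounds shown carry only nitro or cyano at this place, so how an amine or a carboxylic acid there would read in this assay remains open. Also open, from the compounds shown here alone, is whether the step would persist with a longer chain in place of the methyl groups.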